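The source may report more compounds than this note shows. Statements on the series, on what has been measured and on what is new or still open speak of the compounds shown alone.

Compound 1 `CCCC(CCC)C(=O)OCCCOC(=O)c1ccc(C(=O)Nc2ccc3c(c2)C(C)(C)CCC3(C)C)cc1`: in a functional assay on K562 cells (Homo sapiens) for inhibition, read by MTT assay, with a stated time of 48 h (on this read-out higher numbers stand for weaker inhibition and lower numbers for stronger inhibition), gives a limit, > 1000000 nM.
Compound 2 `Cc1cc2c(cc1C(=O)c1ccc(C(=O)OCCOC(=O)c3ccc(C(=O)Nc4ccc5c(c4)C(C)(C)CCC5(C)C)cc3)cc1)C(C)(C)CCC2(C)C`: in this assay gives 39900 nM.

Compound 1 thus stands at a limit of this assay, not at a number (the limit of > 1000000 nM in this assay, at which 1 of the 2 values shown sits); only compound 2 carries a number. Compound 3 `CCCC(CCC)C(=O)OCCOC(=O)c1ccc(C(=O)Nc2ccc3c(c2)C(C)(C)CCC3(C)C)cc1` differs from compound 1 by ((1-propylbutyl)carbonyl)oxy in place of (((1-propylbutyl)carbonyl)oxy)methyl on a saturated chain carbon, two bonds along the chain from an oxygen next to a carbonyl group. Among the compounds with values here, no step between two measured compounds is available to calibrate this change. For compound 3 a step of a number no higher from compound 1 to compound 3 (the limit leaves the size open) of no size beyond the scatter is expected because compound 1 sits at the limit of > 1000000 nM in this assay, at which 1 of the 2 values shown sits. Compound 3 is therefore estimated at 1000000 nM, between 300000 nM and 3000000 nM, most probably reported again only as a limit.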

Compound 3, half-maximal inhibitory concentration: 664000 nM
Compound 3: the middle estimate sits 1.5-fold (0.18 log units) above what was measured; low and high end bracket the measured number.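

In this assay compound 3 gives this chain position a number, 664000 nM. Putting ((1-propylbutyl)carbonyl)oxy in place of (((1-propylbutyl)carbonyl)oxy)methyl gives an at least 1.5-fold lower number from compound 1 to compound 3 (0.17 log units; that floor lies within the scatter), so the shorter chain cannot yet be told apart from the longer one. Compound 1 remains a limit, and the step therefore has only a floor and no measured size: the limit of > 1000000 nM in this assay, at which 1 of the 3 values shown sits.

Going by these compounds, what a longer chain would do at this place remains open. So does the effect of an amine or a carboxylic acid in place of the 1-propylbutyl group.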